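Swapping a pyridine for a chlorophenyl on the shared core

The source may report more compounds than this note shows. Statements on the series, on what has been measured and on what is new or still open speak of the compounds shown alone.

Among the measured compounds shown here, compound 2 `Clc1ccc(-c2cc(-c3cccnc3)nc(-c3cccs3)c2)o1` is the compound with the lower of the two numbers measured so far in a functional assay on HCT-15 cells (Homo sapiens) for cytotoxicity, in the presence of a further agent that is not named here; a lower number here means a stronger inhibitor, a higher number a weaker inhibitor. In this assay compound 2 gives 1240 nM. Its nearest neighbour is compound 3 `Cc1ccccc1-c1cc(-c2ccc(Cl)o2)cc(-c2ccsc2)n1`, which gives 4630 nM in this assay, a gap that lies beyond the usual scatter. Compound 1 `Clc1ccc(-c2cc(-c3ccsc3)nc(-c3ccco3)c2)o1` reaches only a limit of this assay, > 50000 nM, so no number is known for it. For the measured compounds named here, the one measured step, an at least 10-fold lower number from compound 1 to compound 3 (1.03 log units; beyond the scatter), shows that putting a 2-methylphenyl group where a furan-2-yl group had been on the shared core moves the number a long way downward, though the exact size is hidden because compound 1 sits at the limit of > 50000 nM in this assay, at which 1 of the 3 values shown sits.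

Compound 4 `Clc1ccc(-c2cc(-c3cccs3)nc(-c3ccccc3Cl)c2)o1` arises from compound 2 by 2-chlorophenyl in place of pyridin-3-yl on an aromatic carbon. This resembles the step from compound 1 to compound 3 in that a small ring gives way to a phenyl ring bearing one ortho substituent, next to the ring nitrogen, so a move to a lower number is plausible, but compound 2 already starts from the lowest measured value. A modest change, a 1.6-fold lower number from compound 2 to compound 4 (0.19 log units; within the scatter), is expected. Compound 4 is estimated at 800 nM, within 250 nM to 3000 nM.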

Compound 4, half-maximal inhibitory concentration: 6190 nM
Compound 4: the middle estimate sits 7.7-fold (0.89 log units) below what was measured; the whole stated range lies below it.
By their numbers in this assay, from the lowest: compound 2; then compounds 3 and 4 (each within the scatter of the next). At a limit, above all of these: compound 1.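

On this aromatic carbon next to the ring nitrogen, 2-chlorophenyl brings no gain over pyridin-3-yl: the change gives a 5.0-fold higher number from compound 2 to compound 4 (0.70 log units; beyond the scatter) in this assay and so runs the opposite way to the earlier step. That earlier step gave an at least 10-fold lower number from compound 1 to compound 3 (1.03 log units; beyond the scatter) when 2-methylphenyl entered, which shows that a phenyl ring carrying one substituent does not lower the number in every setting. The two steps start from different compounds and replace different groups, so they mark a contrast and not a rule.

On these data alone, a plain phenyl group at this place would separate the loss of the pyridine nitrogen from the arrival of the chlorine, and an amine or a carboxylic acid on that phenyl ring remains open too. Nothing given here explains the rise in the number.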